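A few compounds are considered here, and "the series" means these few. Any claim that something is new, unique, unknown or untested is made for them only; others in the source may bear on it.

Measured so far in a functional assay on MCF7 cells (Homo sapiens) for antiproliferative activity, read by MTT assay, with a stated time of 48 h; a lower number here means a stronger inhibitor, a higher number a weaker inhibitor:
compound 1 `O=C(Nc1cccc(/C=C/C(=O)c2nc3ccccc3[nH]2)c1)c1ccccc1`: 11200 nM
compound 2 `O=C(/C=C/c1cccc(NC(=O)c2ccccc2Cl)c1)c1nc2ccccc2[nH]1`: 4570 nM
compound 3 `O=C(Nc1cccc(/C=C/C(=O)c2nc3ccccc3[nH]2)c1)c1cccc(Br)c1`: 5210 nM

Compound 2 gives the lowest number of the three, but its gap to compound 3 lies within the scatter; only compound 1 stands clearly apart. Compound 4 `O=C(Nc1cccc(/C=C/C(=O)c2nc3ccccc3[nH]2)c1)c1ccc(Br)cc1` differs from compound 2 in one place: 4-bromophenyl in place of 2-chlorophenyl on a carbonyl carbon. Bearing on this are a 2.5-fold lower number from compound 1 to compound 2 (0.39 log units; beyond the scatter) and a 2.1-fold lower number from compound 1 to compound 3 (0.33 log units; beyond the scatter), both modest, and a 1.1-fold higher number from compound 2 to compound 3 (0.06 log units; within the scatter), which shows that exchanging one halophenyl for another barely moved the number. A halophenyl remains in compound 4, so no step beyond the scatter is expected in this assay; the estimate implies a 1.1-fold higher number from compound 2 to compound 4 (0.04 log units; within the scatter). Compound 4 is expected at about 5000 nM, with a range from 2500 nM to 10000 nM.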

Compound 4, half-maximal inhibitory concentration: 7000 nM
Compound 4: middle estimate off by 1.4-fold (0.15 log units), on the low side; low and high end bracket the measured number.
By their numbers in this assay, from the lowest: compounds 2, 3, 4 and 1 (each within the scatter of the next, the first and the last beyond it).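

In this assay, 4-bromophenyl in place of the other halophenyls gives a 1.5-fold higher number from compound 2 to compound 4 (0.19 log units; within the scatter) and a 1.3-fold higher number from compound 3 to compound 4 (0.13 log units; within the scatter), so compound 2, compound 3 and compound 4 stay unresolved from one another. New at this position is a 1.6-fold lower number from compound 1 to compound 4 (0.20 log units; within the scatter): unlike compound 2 and compound 3, compound 4 does not clear the scatter from compound 1, so a halogen on this phenyl does not always give a step beyond it. Nothing available explains this difference.

As far as these compounds go, what an amine or a carboxylic acid on this phenyl would do stays open, as does whether any group here separates from the halophenyl compounds.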